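The compounds below may be only part of what the source reports. "The series", "measured", "known", "first", "only" and "open" are said of these compounds alone.

Series notes. Compound 1 `COc1ccc(C2N=C(SCc3ccccc3)NC(C)=C2C(=O)Nc2ccc(F)cc2)cc1OC` is the lower of the two compounds measured in a functional assay on the whole organism (artery, strain albino) with Rattus norvegicus as the target, with a stated time of 300 min, at a dose of 10 mg/kg by the oral route; a higher number here means more inhibition at the dose given (going by the name of the read-out), a lower number less inhibition; compound 1 gives 7.2%. Among the compounds with values here, compound 2 `COc1ccc(C2N=C(SCc3ccc(Cl)cc3)NC(C)=C2C(=O)Nc2ccc(F)cc2)cc1OC` gives 31.3% in this assay, and the one measured step, a number 24.1 percentage points higher from compound 1 to compound 2 (beyond the scatter), concerns the aryl ring of the benzylsulfanyl group. Compound 3 `CC1=C(C(=O)Nc2ccc(F)cc2)C(c2ccc([N+](=O)[O-])cc2)N=C(SCc2ccccc2)N1` has not yet been measured in this assay. Its change from compound 1 is 4-nitrophenyl in place of 3,4-dimethoxyphenyl on a saturated ring carbon. Within the data shown here, this change sits on a saturated ring carbon of the six-membered non-aromatic ring, a different place from that of the measured step, so the step from compound 1 to compound 2 does not bear on it directly, and no measured pair varies the group on the saturated ring carbon. The expectation therefore rests on compound 1 alone, which gives 7.2%. Compound 3 is expected to give 15% in this assay, within a range from 0% to 40%. The expected step of a number 7.8 percentage points higher from compound 1 to compound 3 (within the scatter) is within the scatter; the range is kept wide because a number 24.1 percentage points higher from compound 1 to compound 2 (beyond the scatter) shows that one change to an aryl group can move this read-out.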

Compound 3, a percentage reported as inhibition, in the whole organism at one dose (the size of the read-out at that dose, not a potency): 38.5%
Compound 3: the middle estimate sits 23.5 percentage points below what was measured, within the range that was stated.
By their numbers in this assay, from the lowest: compound 1; then compounds 2 and 3 (each within the scatter of the next).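

The group on the saturated ring carbon matters in this assay: 4-nitrophenyl in place of 3,4-dimethoxyphenyl brings a number 31.3 percentage points higher from compound 1 to compound 3 (beyond the scatter), so this position can move the read-out and not only the aryl ring of the benzylsulfanyl group. Alongside a number 24.1 percentage points higher from compound 1 to compound 2 (beyond the scatter), there are now two separate places on the core of compound 1 where one change gives a higher number, though each place is represented by a single pair. What in this exchange of aryl groups lies behind the step cannot be said, as nothing measured here bears on a cause.

From the compounds shown here alone, the exchange removes both methoxy groups and introduces the nitro group in one change, so it remains open how much of the step goes with each; an unsubstituted phenyl, a 4-methoxyphenyl or a 4-aminophenyl group on the same carbon would help to separate them. Also open, going by these compounds, is how the 4-chlorobenzylsulfanyl group and the 4-nitrophenyl group behave together on the shared core, and how any of these numbers at a single oral dose would relate to potency.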